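Swapping the Hydroxylated Proline Tail for a Simpler Pyrrolidine

This account rests on a few compounds, and the source may have more. Where it says the series, first, only, none or still open, it means among the compounds named here.

In a functional assay on HepG2 cells (Homo sapiens) for antiproliferative activity, read by CCK-8 assay, with a stated time of 48 h (on this read-out lower numbers stand for stronger inhibition and higher numbers for weaker inhibition), compound 1 `COc1ccc(/C=C\c2cc(OC)c(OC)c(OC)c2)cc1OCc1ccc(CN2C[C@H](O)C[C@@H]2C(=O)O)cc1` gives no measurable number: the assay reports only the limit > 10000 nM. Compound 2 `COc1ccc(/C=C\c2cc(OC)c(OC)c(OC)c2)cc1OCc1ccc(CN2CC[C@H](C(=O)O)C2)cc1` gives 6400 nM in this assay. Among the measured compounds shown here, the one measured step is an at least 1.5-fold lower number from compound 1 to compound 2 (0.19 log units; that floor lies within the scatter), which is the exchange of 2-carboxy-4-hydroxypyrrolidin-1-yl for 3-carboxypyrrolidin-1-yl on a saturated chain carbon bound to an aromatic carbon; because compound 1 sits at the limit (the limit of > 10000 nM in this assay, at which 1 of the 2 values shown sits), the true size of that step is unknown beyond its floor.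

Compound 3 `COc1ccc(/C=C\c2cc(OC)c(OC)c(OC)c2)cc1OCc1ccc(CN2CC[C@@H](C(=O)O)C2)cc1` has not yet been measured in this assay. It differs from compound 1 by 3-carboxypyrrolidin-1-yl in place of 2-carboxy-4-hydroxypyrrolidin-1-yl on a saturated chain carbon bound to an aromatic carbon. This is the same exchange that separates compound 1 from compound 2; compound 3 and compound 2 differ only in the handedness of the single defined stereocentre on the new group. A number in the region of compound 2 is therefore expected, an estimated step of an at least 1.4-fold lower number from compound 1 to compound 3 (0.15 log units; that floor lies within the scatter). The estimate for compound 3 is 7000 nM, with a range from 3000 nM to 15000 nM, and a real chance that the assay again reports only a limit.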

Compound 3, half-maximal inhibitory concentration: 2300 nM
Beside the measured number, compound 3's estimate is 3.0-fold (0.48 log units) above it; the measured number lies below the stated range.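

With 3-carboxypyrrolidin-1-yl on a saturated chain carbon bound to an aromatic carbon, this assay now gives an at least 4.3-fold lower number from compound 1 to compound 3 (0.63 log units; beyond the scatter), so this exchange for 2-carboxy-4-hydroxypyrrolidin-1-yl can produce a step beyond the scatter, which the floor of the earlier step could not show. The new compound also shows that the handedness of the new group matters here, and the modest gap of a 2.8-fold lower number from compound 2 to compound 3 (0.44 log units; beyond the scatter) can be assigned to configuration alone, because nothing else separates the pair: the fact that compounds 2 and 3 differ only in the configuration as drawn The value for compound 1 remains a limit, so the step from it gives only a floor: the limit of > 10000 nM in this assay, at which 1 of the 3 values shown sits.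

The exchange from compound 1 changes more than one feature of the group at once, and a 2-carboxypyrrolidin-1-yl group would help show whether the hydroxy group alone accounts for part of the step. From the compounds shown here alone, it also remains open whether the carboxylic acid is needed at all, a question that a methyl ester or a primary amide on the same pyrrolidine ring could address.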